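The source may report more compounds than this note shows. Statements on the series, on what has been measured and on what is new or still open speak of the compounds shown alone.

Going by the values given here, compound 3, `CC(C)CCn1c(Cn2c(=O)n(C(C)C)c3ccccc32)nc2c(CCC#N)cccc21`, sits at the low end of the three numbers measured so far. In an ADME assay on HEp-2 cells (Homo sapiens) for cytotoxicity (a higher number here means that more compound is tolerated, a lower number that less compound is tolerated), compound 3 gives 2240 nM. Its nearest neighbour is compound 1, `CC(C)CCn1c(Cn2c(=O)n(C(C)C)c3ccccc32)nc2c(CO)cccc21`, which in this assay gives 22000 nM; furthest away is compound 2, `COCc1cccc2c1nc(Cn1c(=O)n(C(C)C)c3ccccc31)n2CCC(C)C`, which gives 26700 nM. Between those two the difference is small: a 1.2-fold higher number from compound 1 to compound 2 (0.08 log units; within the scatter). The drop to compound 3 is clearer: a 9.8-fold lower number from compound 1 to compound 3 (0.99 log units; beyond the scatter), and a 12-fold lower number from compound 2 to compound 3 (1.08 log units; beyond the scatter).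

Compound 4, `CC(C)CCn1c(Cn2c(=O)n(C(C)C)c3ccccc32)nc2c(CCCN)cccc21`, differs from compound 3 in one place: aminomethyl in place of cyano on a saturated chain carbon, two bonds along the chain from an aromatic carbon. The side chain keeps its length; the nitrile at its end becomes a primary amine that brings one hydrogen-bond donor with it.

Among the compounds with values here, the steps that bear on this are the two leading into compound 3. Both show that the nitrile-bearing chain is tolerated less than the shorter chain ending in hydroxy or methoxy, each of which also carries a hydrogen-bond acceptor. Nothing measured here carries an amine, so the direction rests on that analogy alone. Compound 4 is therefore expected to be tolerated somewhat better than compound 3, with an estimated step of a 3.1-fold higher number from compound 3 to compound 4 (0.49 log units; beyond the scatter). For compound 4 the estimate in this assay is 7000 nM, within a range from 2200 nM to 22000 nM.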

Compound 4, half-maximal cytotoxic concentration: 2340 nM
For compound 4 the middle estimate is 3.0-fold (0.48 log units) above the measured one; measured number inside the range.
By their numbers in this assay, from the lowest: compounds 3 and 4 (each within the scatter of the next); then compounds 1 and 2 (each within the scatter of the next).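

In this assay, the 3-aminopropyl chain of compound 4 cannot be told apart from the 2-cyanoethyl chain of compound 3 (a 1.0-fold higher number from compound 3 to compound 4 (0.02 log units; within the scatter)), so at this position, adding a hydrogen-bond donor at the chain end leaves the number inside the usual scatter. Compound 4 also stands well away from the compounds with a methoxy or hydroxy group on the saturated carbon bound to the aromatic carbon (an 11-fold lower number from compound 2 to compound 4 (1.06 log units; beyond the scatter); a 9.4-fold lower number from compound 1 to compound 4 (0.97 log units; beyond the scatter)), which shows that the low number seen with the nitrile also appears with a primary amine in its place. No measurement at hand offers a reason for this result.

The compounds shown leave open whether the number follows the length of the chain or the group that ends it, a question that a 3-hydroxypropyl group, with the hydroxy end of compound 1 on the chain of compound 4, could help to separate. From the compounds shown here alone, how a carboxylic acid at the end of the same chain would behave in this assay also remains open.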